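The source may hold more compounds than are shown below. What is called first, only, known or untested is meant among the compounds shown, and "the series" means these compounds.

Compound 2 `O=S(=O)(Nc1ccc2oc(-c3ccccc3)nc2c1)c1cccc(O)c1` carries a 3-hydroxyphenyl on the sulfonyl sulfur. In an assay on isolated protein for inhibition of malate dehydrogenase, mitochondrial (Sus scrofa), with stated times of 45 min and 30 min (a higher number here means a weaker inhibitor, a lower number a stronger inhibitor), compound 2 gives > 63000 nM, which is a limit of the assay rather than a number. Compound 1 `COc1cccc(S(=O)(=O)Nc2ccc3oc(-c4ccccc4)nc3c2)c1` differs only by a methyl on the oxygen on the aromatic ring. In this assay compound 1 gives > 63000 nM, again a limit. The step that the two limits leave unreadable from compound 1 to compound 2 therefore cannot be sized, and both values sit at the limit of > 63000 nM in this assay, at which 2 of the 2 values shown sit. Compound 3 `COc1ccc(S(=O)(=O)Nc2ccc3oc(-c4ccccc4)nc3c2)cc1` arises through (4-methoxyphenyl in place of 3-hydroxyphenyl on a sulfonyl sulfur). For the measured compounds named here, no measured step is readable, so no shift beyond the scatter is expected. Compound 3 is estimated at 100000 nM, between 30000 nM and 300000 nM. The expected step is a step that the limit leaves unreadable from compound 2 to compound 3.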

Compound 3, half-maximal inhibitory concentration: > 63000 nM
Compound 3: only a limit was reported; the forecaster's own chance of this, stated with the estimate: 85%; the middle value does not contradict the limit.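

No step between compound 1, compound 2 and compound 3 can be read, because each result is only a limit: the limit of > 63000 nM in this assay, at which 3 of the 3 values shown sit.

The compounds shown leave open how strongly any of the three inhibits in this assay, and whether changing the group on the sulfonyl sulfur alters that.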